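The source may hold more compounds than are shown below. What is called first, only, known or untested is meant among the compounds shown, and "the series" means these compounds.

Measured in a physicochemical assay for lipophilicity, read by HPLC, measured as octanol-water partition; on this read-out lower numbers stand for lower lipophilicity and higher numbers for higher lipophilicity:
compound 1 `Nc1ccccc1C(=O)N/N=C/c1ccc2no[n+]([O-])c2c1`: 2
compound 2 `O=C(N/N=C/c1ccc2no[n+]([O-])c2c1)c1ccccc1`: 2.2
compound 3 `Nc1ccc(C(=O)N/N=C/c2ccc3no[n+]([O-])c3c2)cc1`: 1.2

Of these three, compound 3 stands lowest at 1.2, with its gaps to both others beyond the scatter. Compound 4 `O=C(N/N=C/c1ccc2no[n+]([O-])c2c1)c1ccc(O)cc1` has not yet been measured. It differs from compound 3 by a single change, hydroxy in place of amino on an aromatic carbon, para to a large group.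

Going by the values given here, no measured step makes this exchange, so the evidence is indirect. The closest is a number 1.00 log units lower from compound 2 to compound 3 (beyond the scatter), a modest step that comes with amino in place of hydrogen. Also modest is a number 0.80 log units lower from compound 1 to compound 3 (beyond the scatter), with 4-aminophenyl in place of 2-aminophenyl, while a number 0.20 log units higher from compound 1 to compound 2 (within the scatter) stays within the scatter. Compound 4 keeps a group on the carbon where compound 2 carries only hydrogen, and compound 2 reads 2.2, so compound 4 is expected to remain under that value while rising only part of the way towards it. A small upward change is expected, estimated as a number 0.40 log units higher from compound 3 to compound 4 (beyond the scatter). For compound 4 the estimated value is 1.6, with an expected range from 1.2 to 2.1.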

Compound 4, partition coefficient: 1.2
Compound 4: the middle estimate sits 0.40 log units above what was measured, within the range that was stated.
By their numbers in this assay, from the lowest: compounds 3 and 4 (each within the scatter of the next); then compounds 1 and 2 (each within the scatter of the next).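

In this assay, going by these compounds alone, hydroxy in place of amino on an aromatic carbon, para to a large group, gives no change at the digits printed from compound 3 to compound 4 (within the scatter) and so shows that this position does not tell these two groups apart, though the earlier compounds held only amino or hydrogen there. Hydroxy in place of hydrogen at this carbon gives a number 1.00 log units lower from compound 2 to compound 4 (beyond the scatter) and amino in the same place gives a number 1.00 log units lower from compound 2 to compound 3 (beyond the scatter), so a step of the same printed size now appears with two different groups rather than with amino alone. The comparison with the compound that carries the 2-aminophenyl group reads the same way, since the 4-hydroxyphenyl group gives a number 0.80 log units lower from compound 1 to compound 4 (beyond the scatter) and the 4-aminophenyl group gives a number 0.80 log units lower from compound 1 to compound 3 (beyond the scatter) as its counterpart.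

Nothing among the data offers an explanation for the match between amino and hydroxy. As far as these compounds go, it remains open whether a methoxy group, a fluorine atom or a carboxylic acid at this position would read with amino and hydroxy or apart from them, and whether a 2-hydroxyphenyl group would match the 2-aminophenyl group in the same way.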